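A few compounds are considered here, and "the series" means these few. Any claim that something is new, unique, unknown or untested is made for them only; others in the source may bear on it.

Working notes on the series. Compound 3 `CSC(=S)N[C@H]1CCOC1=O` is the smallest member of the set and in a functional assay on MGC-803 cells (Homo sapiens) for cytotoxicity, read by MTT assay, with a stated time of 72 h (a lower number here means a stronger inhibitor, a higher number a weaker inhibitor), it gives only a limit, > 128000 nM, which is the limit of > 128000 nM in this assay, at which 1 of the 3 values shown sits. Among the compounds with values here, compound 1 `Cc1ccc(NC(=O)CSC(=S)N[C@H]2CCOC2=O)cc1` gives 44300 nM and compound 2 `O=C(CSC(=S)N[C@H]1CCOC1=O)Nc1ccc(O)cc1` gives 80000 nM, the single measured step being a 1.8-fold higher number from compound 1 to compound 2 (0.26 log units; within the scatter). Compound 4 `CCCCSC(=S)N[C@H]1CCOC1=O` differs from compound 3 by propyl in place of hydrogen on a saturated chain carbon bound to a sulfur. Within the data shown here, no measured step touches the chain on the sulfur; the step from compound 1 to compound 2 sits on the aromatic ring and does not bear on this change. Compounds 1 and 2, which carry larger groups on the sulfur than compound 3, do return numbers rather than a limit, so a modest move to a lower number is expected, an at least 1.2-fold lower number from compound 3 to compound 4 (0.10 log units; that floor lies within the scatter). Compound 4 is therefore estimated at 100000 nM, with a range of 40000 nM to 250000 nM.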

Compound 4, half-maximal inhibitory concentration: > 128000 nM
Compound 4 ended at the assay's limit (the forecaster's own chance of this, stated with the estimate: 40%); middle value at least 1.2-fold (0.10 log units) away from the limit.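

No step can be read between compound 3 and compound 4 because both values are limits, not numbers: the limit of > 128000 nM in this assay, at which 2 of the 4 values shown sit. The compounds shown leave open whether propyl in place of hydrogen on a saturated chain carbon bound to a sulfur changes the read-out at all.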